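This account rests on a few compounds, and the source may have more. Where it says the series, first, only, none or still open, it means among the compounds named here.

Compound 1 `Cc1cc(=O)cc2c3c1[C@@H](O)[C@H]1[C@@H]3[C@]3(CC2)C(=O)O[C@@H]1CC3C`: > 50000 nM
Compound 2 `Cc1cc(=O)cc2c3c1C[C@@H]1[C@@H]4OC(=O)[C@](C[C@H]2O)(C(C)C4O)[C@H]31`: 38400 nM

Both compounds were tested in a functional assay on HL-60 cells (Homo sapiens) for inhibition, read by CCK-8 assay, with a stated time of 72 h; on this read-out higher numbers stand for weaker inhibition and lower numbers for stronger inhibition. For compound 1 the value > 50000 nM is a limit of the assay rather than a number; (the limit of > 50000 nM in this assay, at which 1 of the 2 values shown sits). Going by the values given here, compound 2 gives the only real number, 38400 nM, which on this read-out means weak inhibition, and it is the only point to start from.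

Compound 3 `Cc1cc(=O)cc2c3c1C[C@H]1[C@@H]3[C@]3(C[C@H]2O)C(=O)O[C@@H]1CC3C` has not yet been measured. It differs from compound 2 in one place: hydrogen in place of hydroxy on a saturated ring carbon. Among the compounds with values here, no measured pair of compounds that differ in one place exists here, so there is nothing to show how such a change moves the read-out. The step from compound 2 to compound 3 is expected to be a 1.0-fold higher number from compound 2 to compound 3 (0.02 log units; within the scatter), that is, no change beyond the usual scatter. Compound 3 is therefore estimated at 40000 nM, with a likely range from 15000 nM to 100000 nM.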

Compound 3, half-maximal inhibitory concentration: > 50000 nM
Compound 3: only a limit was reported (the forecaster's own chance of this, stated with the estimate: 40%); at least 1.2-fold (0.09 log units) between middle value and limit.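

Compound 3 gives only a limit in this assay, > 50000 nM. Going by these compounds alone, as the first pair here that differs in one place, hydrogen in place of hydroxy on this saturated ring carbon gives an at least 1.3-fold higher number from compound 2 to compound 3 (0.11 log units; that floor lies within the scatter), so the change has a floor but no known upper end, and nothing suggests that losing the hydroxy strengthens inhibition. Little can be read about this position from so few real numbers: the limit of > 50000 nM in this assay, at which 2 of the 3 values shown sit.

Only hydroxy and hydrogen are shown at this ring carbon, so it remains open how a methoxy group, an amine or a fluorine atom there would move the number. Also open, going by these compounds, is how much the hydroxy contributes to the weak inhibition by compound 2, as the true value of compound 3 is hidden behind its limit.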